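A few compounds are considered here, and "the series" means these few. Any claim that something is new, unique, unknown or untested is made for them only; others in the source may bear on it.

Working notes on the series. Compound 1 `CNC(=O)c1cc(C(=O)N[C@H]2CC[C@H](O)CC2)n([C@@H](C)c2ccc(Cl)cc2)n1` has been measured in a physicochemical assay for lipophilicity (on this read-out higher numbers stand for higher lipophilicity and lower numbers for lower lipophilicity), where compound 1 gives 3.7. Going by the values given here, compound 2 `CCNC(=O)c1cc(C(=O)NC)nn1[C@@H](C)c1ccccc1` is the only other measured member; in this assay compound 2 gives 3.7. Compound 1 thus stands level with compound 2 at the digits shown, the two values lying within the scatter of each other. No change in a single place between measured compounds is available, and compound 1 and compound 2 differ in more than one place, so their two values show only that they coincide.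

Compound 3 `CNC(=O)c1cc(C(=O)N[C@H]2CC[C@H](O)CC2)n([C@@H](C)c2cccc(C)c2)n1` is the next step from compound 1: 3-methylphenyl in place of 4-chlorophenyl on a saturated chain carbon bound to an aromatic nitrogen and a saturated chain carbon. For this assay the step from compound 1 to compound 3 is expected to be small and, if anything, slightly downward, remaining within the usual scatter, a number 0.15 log units lower from compound 1 to compound 3 (within the scatter). Compound 3 is therefore estimated to give 3.55, with a range from 3.2 to 3.9.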

Compound 3, distribution coefficient: 3.4
Compound 3: middle estimate off by 0.15 log units, on the high side; the measured number falls inside the stated range.
By their numbers in this assay, from the lowest: compounds 3, 1 and 2 (each within the scatter of the next).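

In this assay the series now has its first single-place comparison: on a saturated chain carbon bound to an aromatic nitrogen and a saturated chain carbon, 3-methylphenyl in place of 4-chlorophenyl reads as a number 0.30 log units lower from compound 1 to compound 3 (within the scatter) and so leaves the two compounds indistinguishable on this read-out. Going by these compounds alone, this position therefore tolerates this exchange on this read-out, although the single step changes both the substituent and its place on the phenyl ring, and the two cannot be read apart. No separate measurement bears on this result.

Groups such as 4-methylphenyl or 3-chlorophenyl in this place would be needed to separate the substituent from its location on the ring. From the compounds shown here alone, whether the read-out stays as flat with a carboxylic acid or an aminomethyl group in place of 4-chlorophenyl remains open, as does any reading of the other positions on the shared core.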